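The compounds below may be only part of what the source reports. "The series", "measured", "known", "first", "only" and "open" are said of these compounds alone.

Among the compounds with values here, compound 3 `CCN(c1ccc(C#N)c(Cl)c1)c1cc(-n2ccnc2)ccc1C` is the only member of this small set with a number to show: in an ADME assay on L02 cells (Homo sapiens) for antiproliferative activity, read by CCK-8 assay, with a stated time of 6 days (a higher number here means a weaker inhibitor, a lower number a stronger inhibitor), compound 3 gives 15000 nM. Its two companions, compound 1 `CCN(c1ccc(C#N)c(Cl)c1)c1cc(-c2cnc3ccccc3c2)ccc1C`, for which this assay records "not determined" (no result reported), and compound 2 `CCN(c1ccc(C#N)c(C(F)(F)F)c1)c1cc(-n2ccnc2)ccc1C`, for which this assay records "not determined" (no result reported), share the same overall build but have no result reported here, so compound 3 stands alone and cannot be ranked against them. Compound 4 `CCN(c1ccc(C#N)c(Cl)c1)c1cc(-c2ccnn2C)ccc1C` is the next compound to be tested. It differs from compound 3 in one place: 1-methyl-1H-pyrazol-5-yl in place of 1H-imidazol-1-yl on an aromatic carbon. Within the data shown here, with no comparable step between measured compounds to lean on, the shift in this assay is expected to be modest, a step of no change at the digits printed from compound 3 to compound 4 (within the scatter) that likely stays within the usual scatter in either direction. For compound 4 the value is estimated at 15000 nM, with a plausible range from 5000 nM to 45000 nM.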

Compound 4, half-maximal inhibitory concentration: 6230 nM
Beside the measured number, compound 4's estimate is 2.4-fold (0.38 log units) above it, within the range that was stated.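

In this assay, within the data shown here, the first readable step at this aromatic carbon, putting 1-methyl-1H-pyrazol-5-yl in place of 1H-imidazol-1-yl, gives a 2.4-fold lower number from compound 3 to compound 4 (0.38 log units; beyond the scatter) and so points to a stronger inhibitor. The position therefore responds to the choice of ring, even though both groups are five-membered aromatic rings with the same hydrogen-bond counts. Nothing measured here accounts for the shift. Going by these compounds, it remains open whether the gain comes from the methyl or from the ring itself, and how an amine or a carboxylic acid at this position would read.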